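From Isopropyl to Cyclopropylmethyl on the Pyrrolidine Nitrogen

The compounds below may be only part of what the source reports. "The series", "measured", "known", "first", "only" and "open" are said of these compounds alone.

Three measured compounds share one core and differ only in the group on the amide-type nitrogen. Compound 1 `O=C(N[C@@H]1CCNC1)c1cc(-c2ccc(NS(=O)(=O)c3cccc(Cl)c3Cl)cc2)nc2[nH]ncc12` carries pyrrolidin-3-yl there; in an assay for inhibition of serine/threonine-protein kinase Sgk1 (Homo sapiens), with stated times of 30 min and 60 min, in the presence of a further agent that is not named here (a lower number here means a stronger inhibitor, a higher number a weaker inhibitor), compound 1 gives < 1 nM, which is a limit of the assay rather than a number. Compound 2 `CN1CCC(NC(=O)c2cc(-c3ccc(NS(=O)(=O)c4cccc(Cl)c4Cl)cc3)nc3[nH]ncc23)C1` carries 1-methylpyrrolidin-3-yl; in this assay compound 2 gives < 1 nM, again a limit. Compound 3 `CC(C)N1CC[C@H](NC(=O)c2cc(-c3ccc(NS(=O)(=O)c4cccc(Cl)c4Cl)cc3)nc3[nH]ncc23)C1` carries 1-isopropylpyrrolidin-3-yl; in this assay compound 3 gives 4 nM, the only measured number shown, and since an at least 4.0-fold higher number from compound 1 to compound 3 (0.60 log units; beyond the scatter) and an at least 4.0-fold higher number from compound 2 to compound 3 (0.60 log units; beyond the scatter) both lie beyond the scatter, compound 3 is the weakest of the three. Compound 4 `O=C(NC1CCN(CC2CC2)C1)c1cc(-c2ccc(NS(=O)(=O)c3cccc(Cl)c3Cl)cc2)nc2[nH]ncc12` is not yet measured and differs from compound 3 by 1-(cyclopropylmethyl)pyrrolidin-3-yl in place of 1-isopropylpyrrolidin-3-yl on an amide-type nitrogen. Both measured steps moved toward a weaker inhibitor when 1-isopropylpyrrolidin-3-yl entered, and compound 4 again carries an alkyl group on that nitrogen, so only a small further step is expected, a 1.5-fold higher number from compound 3 to compound 4 (0.18 log units; within the scatter). Compound 4 is therefore estimated at 6 nM, within 1.5 nM to 20 nM.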

Compound 4, half-maximal inhibitory concentration: 1 nM
Estimate against measurement, compound 4: 6.0-fold (0.78 log units) above; measured number outside the range, below it.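

In this assay, the change on this amide-type nitrogen gives a 4.0-fold lower number from compound 3 to compound 4 (0.60 log units; beyond the scatter), so the weaker result for compound 3 is not shared by every alkyl group on the pyrrolidine nitrogen. The entering 1-(cyclopropylmethyl)pyrrolidin-3-yl has one more carbon than the 1-isopropylpyrrolidin-3-yl it replaces, so among these two compounds a larger count of heavy atoms does not go with a higher number. The other two steps are a number no lower from compound 1 to compound 4 (the limit leaves the size open) and a number no lower from compound 2 to compound 4 (the limit leaves the size open) and neither can be read, because each starts from a value that is a limit and not a number: the limit of < 1 nM in this assay, at which 2 of the 4 values shown sit.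

Compound 3 has one defined stereocentre and compound 4 has none, so the shown step cannot separate the change of group from the stereochemistry. From the compounds shown here alone, how a longer chain such as n-butyl, or an acetyl group, on this nitrogen would read also remains open.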